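Naphthalen-2-yl for 4-nitrophenyl: one change on two cores

The source may hold more compounds than are shown below. What is called first, only, known or untested is meant among the compounds shown, and "the series" means these compounds.

Measured so far:
Compound 1, `C=C(CC)C(=O)c1ccc(OCc2nc(-c3ccc([N+](=O)[O-])cc3)cs2)c(C)c1C`: 4.4%
Compound 2, `C=C(CC)C(=O)c1ccc(OCc2nc(-c3ccc4ccccc4c3)cs2)c(C)c1C`: 0%
Compound 3, `C=C(CC)C(=O)c1ccc(OCc2nc(-c3ccc([N+](=O)[O-])cc3)cs2)cc1Cl`: 10.2%

All three were tested in an assay on HL-60 cells for inhibition of glutathione S-transferase P (Homo sapiens), read by spectrophotometry, tested at 5 uM; on this read-out higher numbers stand for more inhibition at the one concentration tested (going by the name of the read-out) and lower numbers for less inhibition. Compound 1 and compound 2 share a core and differ in one group: naphthalen-2-yl in place of 4-nitrophenyl on an aromatic carbon That change gave a number 4.4 percentage points lower from compound 1 to compound 2 (within the scatter). Compound 3 carries a different core; how the two cores differ is not broken down here. Compound 3 has the highest of the three numbers, yet its gap to compound 1 is within the scatter, while its gap to compound 2 lies beyond it.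

Compound 4, `C=C(CC)C(=O)c1ccc(OCc2nc(-c3ccc4ccccc4c3)cs2)cc1Cl`, has not yet been measured. It stands to compound 3 as compound 2 stands to compound 1: naphthalen-2-yl in place of 4-nitrophenyl on an aromatic carbon The surroundings of the change are the same in every word, so this is the same change made on another core. For the measured compounds named here, the only precedent, the step from compound 1 to compound 2, stayed within the scatter. Compound 4 is therefore expected to show an estimated step of a number 4.2 percentage points lower from compound 3 to compound 4 (within the scatter) in this assay. Compound 4 is expected to give 6%, with a range from 0% to 14%.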

Compound 4, a percentage reported as inhibition, at one concentration (the size of the read-out at that concentration, not a potency): 9.5%
For compound 4 the middle estimate is 3.5 percentage points below the measured one, and the stated range covers the measured number.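

In this assay, putting naphthalen-2-yl in place of 4-nitrophenyl gave a number 0.7 percentage points lower from compound 3 to compound 4 (within the scatter). Set beside the earlier case, the change reads the same on both cores, so in this small set its outcome carried over from one core to the other: the same change on two cores in this assay, a number 4.4 percentage points lower (within the scatter) from compound 1 to compound 2 and a number 0.7 percentage points lower (within the scatter) from compound 3 to compound 4, 3.7 percentage points apart, within the scatter of two such steps. This does not show that the change is without any effect or that it would behave the same way on a third core, and a reading at one concentration gives the size of the read-out there, not a potency.

The compounds shown leave open whether a group of a different kind on the same aromatic carbon of the five-membered ring, such as an amine or a carboxylic acid, would move the number beyond the usual scatter. They also leave open whether naphthalen-2-yl and 4-nitrophenyl would still read alike at another concentration.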